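The source may report more compounds than this note shows. Statements on the series, on what has been measured and on what is new or still open speak of the compounds shown alone.

Compound 3 `COc1cc2nc(N3CCN(C(=O)C(C)(C)C)[C@H]4CCCC[C@H]43)nc(N)c2cc1OC` is one of three compounds sharing a core, each carrying an acyl group on an amide-type nitrogen in a ring. In a functional assay (strain Wistar) for antagonist activity at Alpha-1D adrenergic receptor (Rattus norvegicus), with a stated time of 30 min, in the presence of a further agent that is not named here (on this read-out higher numbers stand for weaker binding and lower numbers for tighter binding), compound 3 gives 141 nM, which places it second highest of the three numbers. Compound 2 `CCCCCC(=O)N1CCN(c2nc(N)c3cc(OC)c(OC)cc3n2)[C@@H]2CCCC[C@@H]21`, bearing a pentyl group on the carbonyl carbon, gives 155 nM in this assay, and the step of a 1.1-fold lower number from compound 2 to compound 3 (0.04 log units; within the scatter) shows that swapping pentyl for tert-butyl hardly moved the read-out. Compound 1 `COc1cc2nc(N3CCN(C(C)=O)[C@@H]4CCCC[C@@H]43)nc(N)c2cc1OC`, which carries an acetyl group instead, gives 2.19 nM, far lower than compound 3.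

Compound 4 `COc1cc2nc(N3CCN(C(C)=O)[C@H]4CCCC[C@H]43)nc(N)c2cc1OC` is reached from compound 3 by the change (methyl in place of tert-butyl on a carbonyl carbon). Among the compounds with values here, only one measured step touches the acyl group, the near-flat move from pentyl to tert-butyl, so it offers no guide for going down to methyl. The acetyl compound 1 does, because its 2.19 nM sits well below both larger acyl groups, though compound 1 and compound 4 differ in their spatial arrangement of the ring fusion, so a direct carry-over is uncertain. A clearly lower number is therefore expected for compound 4, with the step of a 9.4-fold lower number from compound 3 to compound 4 (0.97 log units; beyond the scatter) estimated. The estimate for compound 4 is 15 nM, within a range from 3 nM to 80 nM.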

Compound 4, dissociation constant: 1700 nM
Compound 4: the middle estimate sits 110-fold (2.05 log units) below what was measured; the whole stated range lies below it.
By their numbers in this assay, from the lowest: compound 1; then compounds 3 and 2 (each within the scatter of the next); then compound 4.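

In this assay, with the configuration as drawn held fixed, shrinking the group on the carbonyl carbon to methyl weakens binding rather than tightening it: the steps are a 12-fold higher number from compound 3 to compound 4 (1.08 log units; beyond the scatter) and an 11-fold higher number from compound 2 to compound 4 (1.04 log units; beyond the scatter). So among compounds of this configuration, pentyl and tert-butyl both give lower numbers than methyl, even though the two larger groups sit within the scatter of each other. The largest change of all is a 780-fold higher number from compound 1 to compound 4 (2.89 log units; beyond the scatter), and since both compounds carry the same acetyl group, the low number of compound 1 cannot be credited to acetyl alone and instead goes with the configuration, the basis being: the fact that compounds 1 and 4 differ only in the configuration as drawn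

What stays open is whether the order seen among compound 2, compound 3 and compound 4 also holds in the mirror-image configuration of compound 1, where acetyl is the only acyl group shown. Also open, on these data alone, is how an acyl group carrying a ring, such as benzoyl, or a chain ending in an amine would read in either configuration.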